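Replacing Butylcarbamoyl with 4-Bromopyridin-2-yl on the Oxygen

The source may report more compounds than this note shows. Statements on the series, on what has been measured and on what is new or still open speak of the compounds shown alone.

Three measured compounds share one core and differ only in the group joined to the oxygen of the side chain. Compound 1 `COc1nc(C)c(Nc2nc(Cl)cn([C@H](COC(=O)c3ccccc3)C3CC3)c2=O)cc1C` carries a phenyl on the carbonyl carbon there, and in an assay on frontal cortex for displacement of a labelled ligand from corticotropin-releasing factor receptor 1 (Rattus norvegicus), with a stated time of 2 h (on this read-out higher numbers stand for weaker inhibition and lower numbers for stronger inhibition), compound 1 gives 1.5 nM. Compound 2 `COc1nc(C)c(Nc2nc(Cl)cn([C@H](COC(=O)Nc3cccnc3)C3CC3)c2=O)cc1C` gives 10 nM in this assay, and compound 3 `CCCCNC(=O)OC[C@H](C1CC1)n1cc(Cl)nc(Nc2cc(C)c(OC)nc2C)c1=O` gives 4.7 nM. All three steps between them are modest: a 6.7-fold higher number from compound 1 to compound 2 (0.82 log units; beyond the scatter), a 3.1-fold higher number from compound 1 to compound 3 (0.50 log units; beyond the scatter) and a 2.1-fold lower number from compound 2 to compound 3 (0.33 log units; beyond the scatter). Compound 3 therefore stands second highest of the three numbers, nearer to compound 2 than to compound 1.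

Compound 4 `COc1nc(C)c(Nc2nc(Cl)cn([C@H](COc3cc(Br)ccn3)C3CC3)c2=O)cc1C` has not been measured. It differs from compound 3 by 4-bromopyridin-2-yl in place of butylcarbamoyl on an oxygen on a saturated carbon. Going by the values given here, none of the measured steps bears directly on this: each of them only exchanged what sits on the carbonyl carbon, while here the carbonyl and the amide-type nitrogen leave altogether and an aromatic ring attaches straight to the oxygen. Among the compounds with values here, what the three steps do show is that every change at this position so far moved the number only modestly. On that basis compound 4 is expected to land near 3 nM, within a range of 1 nM to 12 nM, which would mean an estimated step of a 1.6-fold lower number from compound 3 to compound 4 (0.19 log units; within the scatter).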

Compound 4, half-maximal inhibitory concentration: 1.5 nM
Beside the measured number, compound 4's estimate is 2.0-fold (0.30 log units) above it; low and high end bracket the measured number.
By their numbers in this assay, from the lowest: compounds 1 and 4 (each within the scatter of the next); then compound 3; then compound 2.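

Until now every group on this oxygen was held through a carbonyl, and compound 4 shows that the carbonyl can go altogether, with an aromatic ring attached straight to the oxygen, while inhibition stays strong in this assay. The exchange for 4-bromopyridin-2-yl gives a 3.1-fold lower number from compound 3 to compound 4 (0.50 log units; beyond the scatter) and a 6.7-fold lower number from compound 2 to compound 4 (0.82 log units; beyond the scatter), so this ring ether outdoes both carbamates, the one with a butyl chain and the one with a pyridin-3-yl ring. Against the benzoyl ester the same exchange gives no change at the digits printed from compound 1 to compound 4 (within the scatter), which means that a ring joined directly to the oxygen and a ring joined through a carbonyl cannot be told apart here, although compound 2 shows that a ring held through a carbamate does not share this result. Nothing shown gives a reason for these shifts.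

Open, on these data alone, is what the bromine adds, which a plain pyridin-2-yl or a chlorine in its place on the same ring would test. Also open, as far as these compounds go, is whether the ring itself matters, which a phenyl or a simple butyl joined straight to the oxygen would begin to answer.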